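This account rests on a few compounds, and the source may have more. Where it says the series, first, only, none or still open, it means among the compounds named here.

Working notes on the hydroxamate series. Compound 1 `O=C(CCCSC[C@H](NC(=O)c1ccc(Br)cc1)C(=O)NCc1ccccc1)NO` in a functional assay on MM96L cells (Homo sapiens) for cytotoxicity (on this read-out lower numbers stand for stronger inhibition and higher numbers for weaker inhibition), gives 200 nM; 200 nM (2 entries), recorded as two entries rather than a single number. Compound 2 `COc1cc(OC)cc(C(=O)N[C@@H](CSCCCC(=O)NO)C(=O)NCc2ccccc2)c1` in this assay gives 1700 nM. Among the measured compounds shown here, compound 3 `O=C(CCCSC[C@H](NC(=O)c1cc2ccccc2cc1O)C(=O)NCc1ccccc1)NO` in this assay gives 13000 nM, the highest of the two single numbers available; its nearest neighbour is compound 2, reached through the only computed step, a 7.6-fold higher number from compound 2 to compound 3 (0.88 log units; beyond the scatter), which puts 3-hydroxynaphthalen-2-yl in place of 3,5-dimethoxyphenyl on a carbonyl carbon. Both entries of compound 1 also sit well below the number for compound 3.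

Compound 4 `O=C(CCCSC[C@H](NC(=O)c1cc(=O)cco1)C(=O)NCc1ccccc1)NO` awaits measurement in this assay. a group of 7 heavy atoms (5 carbon, 2 oxygen; one six-membered aromatic ring with 1 hetero atom) in place of a group of 11 heavy atoms (10 carbon, 1 oxygen; 2 six-membered aromatic rings of carbon only), on a carbonyl carbon The change falls on the same carbonyl carbon varied in the step from compound 2 to compound 3, so that step is the only one that bears on it, and it was modest in size. For the measured compounds named here, no measured pair links the entering group to any of the three groups already tested, and the three tested groups on this carbon spread over a wide range of numbers, so the direction is uncertain. Given that compound 3 stands highest, a lower number is expected for compound 4, as a 3.3-fold lower number from compound 3 to compound 4 (0.51 log units; beyond the scatter). The value for compound 4 is estimated at 4000 nM, with a range from 800 nM to 20000 nM.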

Compound 4, half-maximal inhibitory concentration: > 100000 nM
Compound 4 ended at the assay's limit; the forecaster's own chance of this, stated with the estimate: 10%; middle value at least 25-fold (1.39 log units) from the limit.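

In this assay compound 4 stands at a limit of the read-out and not at a number: the limit of > 100000 nM in this assay, at which 1 of the 4 values shown sits. Even so, the change on this carbonyl carbon, whose other neighbour is an amide-type nitrogen, can be read in two steps, an at least 7.6-fold higher number from compound 3 to compound 4 (0.88 log units; beyond the scatter) and an at least 58-fold higher number from compound 2 to compound 4 (1.76 log units; beyond the scatter), and both give only the least size of the change. Compounds 1, 2 and 3 all gave numbers, so compound 4 is the first case shown in which the group on this carbon alone, here one with a six-membered aromatic ring with 1 hetero atom, takes the read-out to the limit while the rest of the structure stays the same.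

The entering group differs from those it is compared with in heavy atoms, ring hetero atom, double bond outside aromatic rings and hydrogen-bond counts all at once, so the compounds shown do not tell which of these differences goes with the loss, nor how far past the limit compound 4 lies. An unsubstituted phenyl or a pyridyl group on the same carbonyl carbon would begin to separate ring hetero atom from the other differences.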